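The source may hold more compounds than are shown below. What is called first, only, known or untested is meant among the compounds shown, and "the series" means these compounds.

Compound 1 `CCOc1ncc(-c2nc(C(F)(F)F)sc2N2CCN(C(=O)Cn3nccc3C)[C@H](C)C2)cn1` gives 289 nM in an assay on blood for inhibition of C-X-C chemokine receptor type 3 (Homo sapiens), with a stated time of 30 min; on this read-out lower numbers stand for stronger inhibition and higher numbers for weaker inhibition. Compound 2 `CCOc1ncc(-c2nc(C(F)(F)F)sc2N2CCN(C(=O)Cn3nc(C)nc3C)[C@H](C)C2)cn1` gives 364 nM, and compound 3 `CCOc1ncc(-c2nc(C(F)(F)F)sc2N2CCN(C(=O)Cn3cc(Cl)cn3)[C@H](C)C2)cn1` gives 245 nM. Of these three numbers, compound 2 carries the highest, yet this standing means little, since a 1.3-fold higher number from compound 1 to compound 2 (0.10 log units; within the scatter) and a 1.5-fold lower number from compound 2 to compound 3 (0.17 log units; within the scatter) both fall within the scatter, as does a 1.2-fold lower number from compound 1 to compound 3 (0.07 log units; within the scatter). Compound 4 `CCCc1ncc(-c2nc(C(F)(F)F)sc2N2CCN(C(=O)Cn3nc(C)nc3C)[C@H](C)C2)cn1` differs from compound 2 by propyl in place of ethoxy on an aromatic carbon. Within the data shown here, none of the measured steps touches this position; all three exchange the group on a saturated chain carbon bound to a carbonyl carbon, and none moved the number beyond the scatter. Among the measured compounds shown here, no measured step therefore bears directly on the change to compound 4, and the expectation for compound 4 in this assay is a step of about a 1.1-fold higher number from compound 2 to compound 4 (0.04 log units; within the scatter), no larger than the scatter. Compound 4 is estimated at 400 nM, within a range from 150 nM to 1100 nM.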

Compound 4, half-maximal inhibitory concentration: 367 nM
Compound 4: middle estimate off by 1.1-fold (0.04 log units), on the high side; low and high end bracket the measured number.
By their numbers in this assay, from the lowest: compounds 3, 1, 2 and 4 (each within the scatter of the next).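

Among these compounds, the first reading at this position, on an aromatic carbon between two ring nitrogen atoms, shows a 1.0-fold higher number from compound 2 to compound 4 (0.00 log units; within the scatter) in this assay when propyl stands in place of ethoxy. The group's one hydrogen-bond acceptor can thus go, with the heavy-atom count unchanged, without the number moving beyond the scatter. Nothing at hand gives a reason for this. Open, as far as these compounds go, is how an amine, a carboxylic acid or a longer chain would read at this position. Also open, from the compounds shown here alone, is whether the same exchange reads alike with the 4-chloro-1H-pyrazol-1-yl or 5-methyl-1H-pyrazol-1-yl group on the saturated chain carbon.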